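Chalcones with prenylated or plain phenol cores: HepG2 inhibition

This account rests on a few compounds, and the source may have more. Where it says the series, first, only, none or still open, it means among the compounds named here.

Measured compounds:
compound 1 `COc1ccc(/C=C/C(=O)c2c(OC)cc(O)c(CC=C(C)C)c2O)cc1OC` — 13800 nM
compound 2 `COc1cc(OC)c(OC)cc1/C=C/C(=O)c1c(OC)cc(O)c(CC=C(C)C)c1O` — > 50000 nM
compound 3 `COc1cc(O)cc(O)c1C(=O)/C=C/c1ccc(O)cc1` — 40200 nM

In a functional assay on HepG2 cells (Homo sapiens) for inhibition, read by MTT assay, with a stated time of 72 h (on this read-out higher numbers stand for weaker inhibition and lower numbers for stronger inhibition), compound 1 gives 13800 nM. Compound 2 differs from compound 1 by methoxy in place of hydrogen on an aromatic carbon. In this assay compound 2 returns only a limit, > 50000 nM. That limit is the one described by the limit of > 50000 nM in this assay, at which 1 of the 3 values shown sits, so the step of an at least 3.6-fold higher number from compound 1 to compound 2 (0.55 log units; beyond the scatter) is a lower bound on the loss rather than a measured size. Compound 3 carries a different core; the difference between the two cores is not broken down here. In this assay compound 3 gives 40200 nM, the higher of the two numbers that are not limits, and its nearest neighbour is compound 1 with a lower number.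

Compound 4 `COc1cc(/C=C/C(=O)c2c(O)cc(O)cc2OC)ccc1O` has not yet been measured. Compound 4 differs from compound 3 by methoxy in place of hydrogen on an aromatic carbon. This is the same kind of change as that from compound 1 to compound 2, but not the same: in compound 4 the methoxy sits ortho to a hydroxy group and meta to a large group, whereas in compound 2 it sits ortho to a large group and meta and para to a methoxy group. Among the measured compounds shown here, the only measured instance of this kind of change, an at least 3.6-fold higher number from compound 1 to compound 2 (0.55 log units; beyond the scatter), made the number higher. Given that compound 3 already stands at 40200 nM, a step of like direction is expected to carry compound 4 to a still higher number. The step from compound 3 to compound 4 is estimated as a 1.5-fold higher number from compound 3 to compound 4 (0.17 log units; within the scatter). For the measured compounds named here, compound 4 is therefore expected to give about 60000 nM, within 20000 nM to 150000 nM, resting on compound 3 at 40200 nM and on the single precedent an at least 3.6-fold higher number from compound 1 to compound 2 (0.55 log units; beyond the scatter).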

Compound 4, half-maximal inhibitory concentration: > 50000 nM
Compound 4 ended at the assay's limit; the forecaster's own chance of this, stated with the estimate: 60%; the middle value does not contradict the limit.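

In this assay compound 4 returns > 50000 nM, and that value is a limit of the assay. Methoxy in place of hydrogen on an aromatic carbon gives no stronger inhibition on either core, but the new step, an at least 1.2-fold higher number from compound 3 to compound 4 (0.09 log units; that floor lies within the scatter), is only a floor, so this core, where the methoxy sits ortho to a hydroxy group and meta to a large group, does not show a loss beyond the scatter. This does not establish that the size of the change carries from one core to the other, as the two steps can only be set side by side: the same change on two cores in this assay, an at least 3.6-fold higher number (0.55 log units; beyond the scatter) from compound 1 to compound 2 and an at least 1.2-fold higher number (0.09 log units; that floor lies within the scatter) from compound 3 to compound 4; the limit leaves it open whether they differ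

The compounds shown leave open how far inhibition actually falls on either core once the methoxy is present, as the read-out stops at the same limit for much of this small set: the limit of > 50000 nM in this assay, at which 2 of the 4 values shown sit. They also leave open whether a different group on such an aromatic carbon, for example an amine or a carboxylic acid, would lower the number on either core rather than raise it.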